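This account rests on a few compounds, and the source may have more. Where it says the series, first, only, none or still open, it means among the compounds named here.

Compound 1 `O=C(NCCCCc1ccccc1)n1c(-c2ccc(Cl)cc2)coc1=O`: 5 nM
Compound 2 `O=C(NCCCCc1ccccc1)n1cc(-c2ccc(F)cc2)oc1=O`: 185 nM

Of these two, compound 2 stands at the higher number in an assay on isolated protein for inhibition of acid ceramidase (Homo sapiens), read by LC-MS, with a stated time of 1 h (a higher number here means a weaker inhibitor, a lower number a stronger inhibitor), and compound 1 sits at a far lower one, a gap beyond the usual scatter. Compound 3 `COc1cc(-c2cn(C(=O)NCCCCc3ccccc3)c(=O)o2)ccc1F` differs from compound 2 by methoxy in place of hydrogen on an aromatic carbon. For the measured compounds named here, no measured pair shows this change, so its size is not known from the data. Compound 3 is expected to shift by a 1.2-fold lower number from compound 2 to compound 3 (0.09 log units; within the scatter), a step that may not reach beyond the scatter in either direction. Compound 3 is therefore estimated at 150 nM, with a range from 40 nM to 600 nM.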

Compound 3, half-maximal inhibitory concentration: 80 nM
For compound 3 the middle estimate is 1.9-fold (0.27 log units) above the measured one; low and high end bracket the measured number.
By their numbers in this assay, from the lowest: compound 1; then compound 3; then compound 2.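

In this assay the change to 4-fluoro-3-methoxyphenyl gives a 2.3-fold lower number from compound 2 to compound 3 (0.36 log units; beyond the scatter) at this place on the aromatic ring. This shows that the position ortho to the fluoro group accepts methoxy without any loss, and that the added group moves compound 3 modestly towards a stronger inhibitor.

The compounds shown leave open whether hydroxy, ethoxy or an amine at the same carbon would match methoxy, and whether the step holds without the fluoro group. Nothing available explains the step.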